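A few compounds are considered here, and "the series" means these few. Any claim that something is new, unique, unknown or untested is made for them only; others in the source may bear on it.

Measured so far in a functional assay on PRK cells (Oryctolagus cuniculus) for cytotoxicity; on this read-out higher numbers stand for lower toxicity in this test and lower numbers for higher toxicity in this test:
compound 1 `CCCCCCCCOC(=O)C(O)Cn1cnc2c(N)ncnc21`: 100 ug/mL
compound 2 `COCCOC(=O)C(O)Cn1cnc2c(N)ncnc21`: > 400 ug/mL

The value given for compound 2 is a limit of this assay and not a number, as the limit of > 400 ug/mL in this assay, at which 1 of the 2 values shown sits, records. Among the measured compounds shown here, compound 2 thus stands at the less toxic end of the two measured values, reached through an at least 4.0-fold higher number from compound 1 to compound 2 (0.60 log units; beyond the scatter), the only measured step and the one that bears on the question below.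

Compound 3 `CC(C)COC(=O)C(O)Cn1cnc2c(N)ncnc21` differs from compound 2 by isopropyl in place of methoxymethyl on a saturated chain carbon bound to an oxygen next to a carbonyl group. Isopropyl in place of methoxymethyl returns to a carbon-only chain, yet one much smaller than the hexyl of compound 1, so the large drop in toxicity seen from compound 1 to compound 2 is not expected to be reversed. For compound 3 the estimate in this assay is 400 ug/mL (150 ug/mL to 800 ug/mL), an expected step of a number no higher from compound 2 to compound 3 (the limit leaves the size open), within the scatter, with a fair chance that only a limit is again reported.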

Compound 3, minimum cytotoxic concentration: > 400 ug/mL
Compound 3: only a limit was reported; the forecaster's own chance of this, stated with the estimate: 55%; the middle value sits exactly at the limit.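

In this assay, isopropyl in place of heptyl gives an at least 4.0-fold higher number from compound 1 to compound 3 (0.60 log units; beyond the scatter). A carbon-only group at this position therefore reaches the same limit as compound 2, so the oxygen of methoxymethyl is not required for the higher number seen against compound 1. Compound 2 and compound 3 are both reported only as a limit and not as a number, so the step between them cannot be read and methoxymethyl and isopropyl cannot be ranked here: the limit of > 400 ug/mL in this assay, at which 2 of the 3 values shown sit.

Open, going by these compounds, is whether a butyl or pentyl chain at this position reads like compound 2 and compound 3 or moves toward compound 1, which gives 100 ug/mL. Also open, on these data alone, is how a group carrying an amine or a carboxylic acid would read in this assay.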